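The source may hold more compounds than are shown below. What is called first, only, known or untested is meant among the compounds shown, and "the series" means these compounds.

Measured so far:

compound 1, `CCCc1nc(C)c2c(C3CC3)nnc(O)n12` — > 48000 nM
compound 2, `CCc1nnc(O)n2c(CC)nc(C)c12` — 24000 nM

Of the compounds shown here, two have been tested in a functional assay for inhibition, with Homo sapiens as the target; a lower number here means a stronger inhibitor, a higher number a weaker inhibitor. Compound 1 gives > 48000 nM, and this figure is a limit of the assay rather than a measured number; the result is summed up by the limit of > 48000 nM in this assay, at which 1 of the 2 values shown sits. Compound 2 gives 24000 nM in this assay, a weak result that does at least sit inside the measurable range. Compound 1 and compound 2 differ in more than one place, so no single step can be read between them; their two values show only that both are weak inhibitors.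

Compound 3, `CCCc1nc(C)c2c(C)nnc(O)n12`, differs from compound 1 in one place: methyl in place of cyclopropyl on an aromatic carbon. Within the data shown here, no measured pair in this set isolates such a change, so the expectation rests on the weakness of compound 1 alone. The step that the limit leaves unreadable from compound 1 to compound 3 is expected to be small, within the usual scatter, with no clear direction. Compound 3 is therefore estimated to give 50000 nM, with a likely range from 18000 nM to 150000 nM, and it may well again return only a limit.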

Compound 3, half-maximal inhibitory concentration: 14000 nM
Beside the measured number, compound 3's estimate is 3.6-fold (0.55 log units) above it, and the stated range ends above it.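

Among these compounds, replacing cyclopropyl with methyl on this aromatic carbon, para to the hydroxy group, gives the first step in the set that can be read in this assay: an at least 3.4-fold lower number from compound 1 to compound 3 (0.53 log units; beyond the scatter), and this step lies beyond the usual scatter. This shows that the group at this position is not a matter of indifference, as the compound carrying methyl has the lower number and is therefore the stronger inhibitor of the pair. The step gives only a minimum size, and the value for compound 1 is a limit of the assay: the limit of > 48000 nM in this assay, at which 1 of the 3 values shown sits.

One pair cannot tell whether the lower number goes with the loss of the three-membered ring or with the smaller count of heavy atoms, and it gives no trend across other groups at this carbon. As far as these compounds go, how an amine or a butyl chain would read at the same place remains open, and so does whether any group there could give a much lower number than compound 3, which gives 14000 nM in this assay.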